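The source may report more compounds than this note shows. Statements on the series, on what has been measured and on what is new or still open speak of the compounds shown alone.

Measured in a functional assay on RT-112 cells (Homo sapiens) for antiproliferative activity, read by MTT assay, with a stated time of 72 h; on this read-out higher numbers stand for weaker inhibition of growth and lower numbers for stronger inhibition of growth:
- Compound 1 `COc1cc(Nc2ncnc3c(NC(=O)Nc4ccc(Cl)c(C(F)(F)F)c4)cccc23)cc(OC)c1`: > 20000 nM, a limit of the assay
- Compound 2 `COc1cc(Nc2ncnc3c(NC(=O)Nc4ccc(Cl)c(Cl)c4)cccc23)cc(OC)c1`: 6230 nM

Going by the values given here, compound 2 holds the only true number so far, as the other entry is a limit. The next compound, compound 3 `COc1cc(Nc2ncnc3c(NC(=O)Nc4ccc(C(F)(F)F)cc4Cl)cccc23)cc(OC)c1`, keeps the shared core but carries a new group: 2-chloro-4-(trifluoromethyl)phenyl in place of 3,4-dichlorophenyl on an amide-type nitrogen. In words, 2-chloro-4-(trifluoromethyl)phenyl stands in place of 3,4-dichlorophenyl on an amide-type nitrogen. Among the compounds with values here, one measured step bears on this change: an at least 3.2-fold lower number from compound 1 to compound 2 (0.50 log units; beyond the scatter), where chloro replaced trifluoromethyl on an aromatic carbon. Compound 3 brings a trifluoromethyl group back, so that step points towards a higher number, although the two changes are not identical and the match is only partial. The expected step is a 1.8-fold higher number from compound 2 to compound 3 (0.25 log units; within the scatter) in this assay. For compound 3 the estimated value is 11000 nM, with an expected range of 3500 nM to 30000 nM.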

Compound 3, concentration for 50% growth inhibition: 1080 nM
Compound 3: middle estimate off by 10-fold (1.01 log units), on the high side; measured number outside the range, below it.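

Compound 3 shows that a trifluoromethyl group on this aryl ring need not weaken growth inhibition in this assay: replacing 3,4-dichlorophenyl on the amide-type nitrogen with 2-chloro-4-(trifluoromethyl)phenyl gives a 5.8-fold lower number from compound 2 to compound 3 (0.76 log units; beyond the scatter). The arrangement of the groups on the ring therefore matters, since 4-chloro-3-(trifluoromethyl)phenyl and 2-chloro-4-(trifluoromethyl)phenyl carry the same two groups, yet exchanging the first for the second gives an at least 18-fold lower number from compound 1 to compound 3 (1.26 log units; beyond the scatter). Compound 1 stands at a limit of the assay and not a number, so that step has no upper size: the limit of > 20000 nM in this assay, at which 1 of the 3 values shown sits.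

The compounds shown do not separate the contribution of the chloro from that of the trifluoromethyl in 2-chloro-4-(trifluoromethyl)phenyl. Going by these compounds, it also remains open whether a methoxy group, an amine or a carboxylic acid could take the place of either group and keep this level of growth inhibition.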